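The compounds below may be only part of what the source reports. "The series", "measured", "known", "first", "only" and "open" are said of these compounds alone.

Of the compounds shown here, three that share one macrocyclic core have been tested in an assay on Sf9 cells for inhibition of protein deacetylase HDAC6 (Homo sapiens), read by fluorescence, with a stated time of 2 h; a higher number here means a weaker inhibitor, a lower number a stronger inhibitor. Compound 1 `O=C(O)c1cccc(NCCOc2ccc3cc2COC/C=C/COCc2cccc(c2)-c2ccnc(n2)N3)c1` gives 53000 nM. Compound 2 `O=C(NO)c1cccc(NCCOc2ccc3cc2COC/C=C/COCc2cccc(c2)-c2ccnc(n2)N3)c1` gives 2900 nM. Compound 3 `O=C(CCCCCOc1ccc2cc1COC/C=C/COCc1cccc(c1)-c1ccnc(n1)N2)NO` gives 28 nM, the lowest of the three numbers; the nearest neighbour is reached by a 100-fold lower number from compound 2 to compound 3 (2.02 log units; beyond the scatter), the furthest by a 1900-fold lower number from compound 1 to compound 3 (3.28 log units; beyond the scatter).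

Compound 4 `O=C(O)CCCCCCOc1ccc2cc1COC/C=C/COCc1cccc(c1)-c1ccnc(n1)N2` differs from compound 3 in one place: carboxymethyl in place of hydroxycarbamoyl on a saturated chain carbon, five bonds along the chain from an oxygen on an aromatic ring. The measured step that bears on this swap is an 18-fold lower number from compound 1 to compound 2 (1.26 log units; beyond the scatter), where hydroxyamino replaced hydroxy on a carbonyl carbon and the number fell sharply. Among the compounds with values here, the change from compound 3 to compound 4 runs the other way, from a hydroxycarbamoyl group to an acid, so a rise of comparable size is expected; no measured pair speaks to the single added chain carbon on its own. Compound 4 is therefore expected to give about 1000 nM, with a likely range from 200 nM to 10000 nM. That expectation amounts to an estimated step of a 36-fold higher number from compound 3 to compound 4 (1.55 log units; beyond the scatter).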

Compound 4, half-maximal inhibitory concentration: 2800 nM
The estimate for compound 4 lay 2.8-fold (0.45 log units) below the measured number; the measured number falls inside the stated range.
By their numbers in this assay, from the lowest: compound 3; then compounds 4 and 2 (each within the scatter of the next); then compound 1.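

Read in this assay, the change at this place on the saturated chain gives a 100-fold higher number from compound 3 to compound 4 (2.00 log units; beyond the scatter), so the hydroxycarbamoyl end matters on this chain as well as on the aromatic side chain of compound 2. The chain's advantage is also not tied to hydroxycarbamoyl, since two compounds that both end in a carboxylic acid show a 19-fold lower number from compound 1 to compound 4 (1.28 log units; beyond the scatter) when 4-carboxybutyl takes the place of (3-carboxyphenyl)amino. The step of a 1.0-fold lower number from compound 2 to compound 4 (0.02 log units; within the scatter) then places the acid on the saturated chain level with the hydroxycarbamoyl on the aromatic side chain.

Nothing available here explains why any of these steps has its size. As far as these compounds go, the swap from compound 3 to compound 4 changes the end group and the chain length together, so a 3-carboxypropyl chain would be needed to separate them, and the effect of an amine at the chain end remains unknown.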